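Swapping the Benzyl Ring Substituent: Compound 3 to Compound 4

The source may hold more compounds than are shown below. What is called first, only, known or untested is meant among the compounds shown, and "the series" means these compounds.

Compound 1 `O=c1ccoc2cc(OCc3cn(Cc4ccccc4)nn3)ccc12`: in a functional assay on A549 cells (Homo sapiens) for cytotoxicity, read by MTT assay, with a stated time of 48 h (a lower number here means a stronger inhibitor, a higher number a weaker inhibitor), compound 1 gives > 100000 nM, a limit of the assay.
Compound 2 `Cc1ccc(Cn2cc(COc3ccc4c(=O)ccoc4c3)nn2)cc1`: in this assay compound 2 gives 50700 nM.
Compound 3 `O=c1ccoc2cc(OCc3cn(Cc4ccc(F)cc4)nn3)ccc12`: in this assay compound 3 gives > 100000 nM, again a limit.

Compound 3 thus sits at the limit of > 100000 nM in this assay, at which 2 of the 3 values shown sit. Compound 4 `O=c1ccoc2cc(OCc3cn(Cc4ccccc4Cl)nn3)ccc12` differs from compound 3 by 2-chlorophenyl in place of 4-fluorophenyl on a saturated chain carbon bound to an aromatic nitrogen. Within the data shown here, two measured steps touch the same ring as this change: a step that the two limits leave unreadable from compound 1 to compound 3 and an at least 1.9-fold higher number from compound 2 to compound 3 (0.29 log units; that floor lies within the scatter). Among the measured compounds shown here, the only other step on that ring, an at least 1.9-fold lower number from compound 1 to compound 2 (0.29 log units; that floor lies within the scatter), is small. Nothing among these compounds suggests that exchanging one halogen for another would pull compound 4 far from the limit. Compound 4 is therefore expected to remain weak, with an estimated at least 1.2-fold lower number from compound 3 to compound 4 (0.09 log units; that floor lies within the scatter) and an estimated value of 80000 nM, ranging from 20000 nM to 300000 nM.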

Compound 4, half-maximal inhibitory concentration: > 100000 nM
Compound 4 was reported as a limit; the forecaster's own chance of this, stated with the estimate: 60%; middle value at least 1.2-fold (0.09 log units) from the limit.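

In this assay, compound 4 gives > 100000 nM, a limit of the assay, so a chlorine-bearing benzyl group also gives no measurable value here: the limit of > 100000 nM in this assay, at which 3 of the 4 values shown sit. The steps linking compound 4 to compound 1 and to compound 3 cannot be read, with limits at both ends. Among these compounds, the only readable step, an at least 1.9-fold higher number from compound 2 to compound 4 (0.29 log units; that floor lies within the scatter), does not clearly set compound 2 apart.

The compounds shown leave open how far those limit compounds differ from one another. Also open, on these data alone, is whether an amine or a carboxylic acid on the benzyl ring, or a longer chain in place of the benzyl group, would give a clear value.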